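Moving the fluorine: from compound 1 to compound 4

This account rests on a few compounds, and the source may have more. Where it says the series, first, only, none or still open, it means among the compounds named here.

Measured in a physicochemical assay, with a stated time of 10 min; a higher number here means a weaker inhibitor, a lower number a stronger inhibitor:
- compound 1 `C/C(=N\N=C1/SCC(=O)N1Cc1cccc(F)c1)c1cccs1` gives 4640000 nM
- compound 2 `CC(C)=N/N=C1\SCC(=O)N1Cc1ccc(N)cc1` gives > 5000000 nM
- compound 3 `C/C(=N/N=C1\SCC(=O)N1Cc1ccc(F)cc1)c1cccs1` gives 3900000 nM

Only two of these results are numbers. Compound 1 at 4640000 nM and compound 3 at 3900000 nM lie within the scatter of each other, so compound 1 has a single close neighbour and no clear rank. The result for compound 2 is a limit of the assay, not a number (> 5000000 nM).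

Compound 4 `C/C(=N\N=C1/SCC(=O)N1Cc1ccccc1F)c1cccs1` has the same atoms as compound 1, joined differently: 2-fluorophenyl in place of 3-fluorophenyl on a saturated chain carbon bound to an amide-type nitrogen in a ring. Going by the values given here, no measured pair differs in one place alone, so the size of this change in this assay has no direct precedent. No step beyond the scatter is expected, and no direction is favoured. This expectation rests on the closeness of compound 3 (3900000 nM) to compound 1 (4640000 nM). The estimated step is a 1.2-fold lower number from compound 1 to compound 4 (0.06 log units; within the scatter) and it is expected to stay within the scatter. Compound 4 is expected at an estimated 4000000 nM, with a range of 2000000 nM to 5000000 nM.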

Compound 4, half-maximal inhibitory concentration: 3840000 nM
Estimate against measurement, compound 4: 1.0-fold (0.02 log units) above; the measured number falls inside the stated range.
By their numbers in this assay, from the lowest: compounds 4, 3 and 1 (each within the scatter of the next). At a limit, above all of these: compound 2.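

In this assay, 2-fluorophenyl in place of 3-fluorophenyl on a saturated chain carbon bound to an amide-type nitrogen in a ring gives a 1.2-fold lower number from compound 1 to compound 4 (0.08 log units; within the scatter). Going by these compounds alone, this is the first step that can be read at one place, and it shows that this change of fluorine position does not separate the two compounds. The step says little about a possible weakening at this place, because the numbers of compound 1 and compound 4 lie close to the top of what the assay reports: the limit of > 5000000 nM in this assay, at which 1 of the 4 values shown sits.

On these data alone, whether this place can give a clearly different number remains open, and a carboxylic acid or a longer chain there would test it. Compound 2 differs from the others in more than one place and its result is a limit, so its steps cannot be read.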